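Compound 2 without its (1-bromoethenyl)carbonyl group

The compounds below may be only part of what the source reports. "The series", "measured", "known", "first", "only" and "open" are said of these compounds alone.

In a functional assay on FM3A cells (Mus musculus) for antiproliferative activity, with a stated time of 48 h (a higher number here means a weaker inhibitor, a lower number a stronger inhibitor), compound 1 (`C=C(Br)C(=O)Nc1ccc(/C=C/C(=O)c2cccc(OC)c2)cc1`) gives 2700 nM as the highest number of the three measured. Compound 2 (`C=C(Br)C(=O)Nc1ccc(/C=C/C(=O)c2cc(OC)c(OC)c(OC)c2)cc1`) gives 950 nM and compound 3 (`C=C(Br)C(=O)Nc1ccc(/C=C/C(=O)c2cccs2)cc1`) gives 520 nM in the same test, so compound 2 lies within the scatter of compound 3 and well under compound 1.

Compound 4 (`COc1cc(C(=O)/C=C/c2ccc(N)cc2)cc(OC)c1OC`) has hydrogen in place of (1-bromoethenyl)carbonyl on a nitrogen on an aromatic ring. Going by the values given here, the only measured step is a 5.2-fold lower number from compound 1 to compound 3 (0.72 log units; beyond the scatter) for thiophen-2-yl in place of 3-methoxyphenyl on a carbonyl carbon. That change lies elsewhere in the structure, so it serves only as a gauge of size. All three measured compounds carry the (1-bromoethenyl)carbonyl group, and no measurement shows what its removal does.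

A higher number in this assay is nevertheless expected, somewhat larger than that measured step and with wide uncertainty. The expected change is an 8.4-fold higher number from compound 2 to compound 4 (0.93 log units; beyond the scatter) on this reasoning. For compound 4 the estimated value is 8000 nM with a range of 2000 nM to 30000 nM as the working expectation.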

Compound 4, half-maximal inhibitory concentration: 36000 nM
The estimate for compound 4 lay 4.5-fold (0.65 log units) below the measured number; the whole stated range lies below it.
By their numbers in this assay, from the lowest: compounds 3 and 2 (each within the scatter of the next); then compound 1; then compound 4.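

In this assay, going by these compounds alone, hydrogen in place of (1-bromoethenyl)carbonyl on the nitrogen on the aromatic ring gives a 38-fold higher number from compound 2 to compound 4 (1.58 log units; beyond the scatter), the first direct reading of this group's contribution. Within this set, that change counts for more than the swap on the carbonyl carbon, which gave a 5.2-fold lower number from compound 1 to compound 3 (0.72 log units; beyond the scatter). Nothing available explains the size of the step at this position.

As far as these compounds go, it remains open which part of the removed group carries the step: the bromine, the double bond or the carbonyl; an acetyl or a propanoyl group on the same nitrogen would help separate these parts. From the compounds shown here alone, the step is also read on compound 2 alone, so its size with the thiophen-2-yl group of compound 3 or the 3-methoxyphenyl group of compound 1 stays open.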